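A few compounds are considered here, and "the series" means these few. Any claim that something is new, unique, unknown or untested is made for them only; others in the source may bear on it.

Working notes on the thiourea series. Compound 1 `O=C(NC(=S)N1CCc2c(OCCCCCOc3ccc(Cl)cc3)cccc21)c1cccc([N+](=O)[O-])c1` gives 12100 nM in an ADME assay on Huh-7 cells (Homo sapiens) for cytotoxicity; a lower number here means that less compound is tolerated, a higher number that more compound is tolerated. Compound 2 `N#Cc1ccc(C(=O)NC(=S)N2CCc3c(OCCCCCOc4ccc(Cl)cc4)cccc32)cc1` reaches only the limit > 50000 nM in this assay, a limit rather than a number (the limit of > 50000 nM in this assay, at which 1 of the 3 values shown sits). Compound 3 `COc1ccc(C(=O)NC(=S)N2CCc3c(OCCCCCOc4ccc(Cl)cc4)cccc32)cc1` gives 34400 nM, the highest of the two plain numbers recorded; its nearest neighbour is compound 1, with a 2.8-fold higher number from compound 1 to compound 3 (0.45 log units; beyond the scatter). The step of an at least 4.1-fold higher number from compound 1 to compound 2 (0.61 log units; beyond the scatter) is the other measured change on the carbonyl carbon, and an at least 1.4-fold lower number from compound 2 to compound 3 (0.16 log units; that floor lies within the scatter) stays within the scatter.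

Compound 4 `O=C(NC(=S)N1CCc2c(OCCCCCOc3ccc(Cl)cc3)cccc21)C1CCCC1` differs from compound 3 by cyclopentyl in place of 4-methoxyphenyl on a carbonyl carbon. Both measured steps that bear on it, the change from compound 1 to compound 3 and from compound 1 to compound 2, only exchange one aromatic substituent for another on that carbonyl carbon and were modest; none of them replaces the aromatic ring by a non-aromatic one. The expectation is therefore a step of a 1.0-fold lower number from compound 3 to compound 4 (0.02 log units; within the scatter) that does not clearly exceed the scatter in this assay. Compound 4 is estimated at 33000 nM in this assay, within 12000 nM to 50000 nM.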

Compound 4, half-maximal cytotoxic concentration: > 50000 nM
Compound 4 ended at the assay's limit (the forecaster's own chance of this, stated with the estimate: 35%); middle value at least 1.5-fold (0.18 log units) from the limit.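

Compound 4 is the only compound shown with a non-aromatic ring on the carbonyl carbon, and its result in this assay is a limit of the assay rather than a number: the limit of > 50000 nM in this assay, at which 2 of the 4 values shown sit.

Exchanging the aromatic ring for cyclopentyl gives an at least 4.1-fold higher number from compound 1 to compound 4 (0.61 log units; beyond the scatter), which lies beyond the scatter, and an at least 1.4-fold higher number from compound 3 to compound 4 (0.16 log units; that floor lies within the scatter), whose floor lies within it. At this position, therefore, an aromatic ring is not required to keep the number high, and the step between compound 2 and compound 4 cannot be read, as both are limits.

The order of compound 2 and compound 4 stays unresolved, and the separation of compound 3 from compound 4 remains unproven. Also open, on these data alone, is how an open alkyl chain, or a cyclopentyl ring carrying an amine or a carboxylic acid, would behave on this carbonyl carbon.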